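This account rests on a few compounds, and the source may have more. Where it says the series, first, only, none or still open, it means among the compounds named here.

Working notes on the series. Compound 3 `CC(C)N(C(=O)C1CCCCCC1)c1cc(C#CC(C)(C)C)sc1C(=O)O` carries cycloheptyl on a carbonyl carbon. In an ADME assay on MT4 cells (Homo sapiens) for cytotoxicity, with a stated time of 5 days (on this read-out higher numbers stand for lower toxicity in this test and lower numbers for higher toxicity in this test), compound 3 gives > 20000 nM, which is a limit of the assay and not a number. Compound 1 `CC1CC=C(C(=O)N(c2cc(C#CC(C)(C)C)sc2C(=O)O)C(C)C)CC1` gives > 20000 nM in this assay, again a limit. Compound 2 `CC(C)N(C(=O)[C@H]1CC[C@@H]2C[C@@H]2CC1)c1cc(C#CC(C)(C)C)sc1C(=O)O` gives > 20000 nM in this assay, also a limit. Every value shown so far sits at the limit of > 20000 nM in this assay, at which 3 of the 3 values shown sit. Accordingly the step that the two limits leave unreadable from compound 1 to compound 3 and the step that the two limits leave unreadable from compound 2 to compound 3 cannot be read, and the same holds for a step that the two limits leave unreadable from compound 1 to compound 2: replacing 4-methylcyclohex-1-en-1-yl by cycloheptyl, or by the group with one three-membered and one seven-membered ring, has not moved any compound off the limit in this assay.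

Compound 4 `CC(C)N(C(=O)C1CCC(F)(F)CC1)c1cc(C#CC(C)(C)C)sc1C(=O)O` is not yet measured. The change from compound 3 is 4,4-difluorocyclohexyl in place of cycloheptyl on a carbonyl carbon. The measured steps that bear on it, those leading into compound 3, all run between limits and give no readable size; none points in either direction. For compound 4 the expected step that the limit leaves unreadable from compound 3 to compound 4 is therefore no movement beyond the scatter, the most probable outcome being one more limit. Compound 4 is estimated at 30000 nM in this assay, with a range from 15000 nM to 100000 nM.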

Compound 4, half-maximal cytotoxic concentration: > 20000 nM
Compound 4 gave a limit, no number (the forecaster's own chance of this, stated with the estimate: 85%); the middle value lies beyond the limit too.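

In this assay compound 4 gives > 20000 nM, a limit of the assay and not a number. No step from compound 1, compound 2 or compound 3 to compound 4 can be read: the limit of > 20000 nM in this assay, at which 4 of the 4 values shown sit.

The compounds shown leave open how far any of the four lies beyond that limit, and whether any group on the carbonyl carbon changes the read-out in this assay.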